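The compounds below may be only part of what the source reports. "The series", "measured", "known", "first", "only" and "open" are said of these compounds alone.

In a functional assay (aorta) with Rattus norvegicus as the target (a lower number here means a stronger inhibitor, a higher number a weaker inhibitor), compound 1 `CC1(C)Oc2ccc(C#N)cc2[C@@H](/N=C(\NC#N)Oc2ccccc2)[C@@H]1O` gives only a limit of > 100000 nM.

Compound 3 `CSc1ccc(N/C(=N/[C@@H]2c3cc(C#N)ccc3OC(C)(C)[C@H]2O)NC#N)cc1` stands at 6300 nM, level within the scatter with compound 2 `CC1(C)Oc2ccc(C#N)cc2[C@@H](/N=C(\NC#N)Nc2ccc(N)cc2)[C@@H]1O` at 3500 nM.

Compound 4 `CC1(C)Oc2ccc(C#N)cc2[C@@H](/N=C(\NC#N)Nc2ccc(Cl)c(F)c2)[C@@H]1O` carries 4-chloro-3-fluorophenyl in place of 4-(methylsulfanyl)phenyl on an amine nitrogen.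

The closest measured change is a 1.8-fold higher number from compound 2 to compound 3 (0.26 log units; within the scatter), where methylsulfanyl replaced amino on an aromatic carbon and the number stayed within the scatter. The large steps of an at least 28-fold lower number from compound 1 to compound 2 (1.45 log units; beyond the scatter) and an at least 15-fold lower number from compound 1 to compound 3 (1.20 log units; beyond the scatter) replaced phenoxy, a change not repeated here, since compound 4 keeps the amine nitrogen. Among the compounds with values here, no measured compound yet carries chlorine or fluorine, so no step beyond the scatter is expected, and the expected step is a 1.8-fold lower number from compound 3 to compound 4 (0.26 log units; within the scatter).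

For compound 4 the estimate is 3500 nM, with an expected range of 900 nM to 14000 nM.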

Compound 4, half-maximal inhibitory concentration: 1660 nM
For compound 4 the middle estimate is 2.1-fold (0.32 log units) above the measured one; measured number inside the range.
By their numbers in this assay, from the lowest: compound 4; then compounds 2 and 3 (each within the scatter of the next). At a limit, above all of these: compound 1.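

Within the data shown here, on the amine nitrogen, 4-chloro-3-fluorophenyl is the first group in this assay to stand apart beyond the scatter from the other substituted phenyl groups, with a 3.8-fold lower number from compound 3 to compound 4 (0.58 log units; beyond the scatter) and a 2.1-fold lower number from compound 2 to compound 4 (0.32 log units; beyond the scatter) as modest steps. Among these compounds, compounds 2 and 3 had stayed level within the scatter, so changing the phenyl substituent had so far moved nothing measurable. The step of an at least 60-fold lower number from compound 1 to compound 4 (1.77 log units; beyond the scatter) is only a bound, since the value for compound 1 is a limit: the limit of > 100000 nM in this assay, at which 1 of the 4 values shown sits.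

Chlorine and fluorine enter together, so the share of each stays open. A phenyl carrying chlorine alone or fluorine alone, a bare phenyl, and a phenyl carrying a carboxylic acid all lie outside the compounds shown.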